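Swapping the furanylmethyl arm: an expectation for compound 4

The compounds below may be only part of what the source reports. "The series", "measured", "known", "first", "only" and "open" are said of these compounds alone.

Of the compounds shown here, three have been tested in a functional assay on MDA-MB-231 cells (Homo sapiens) for inhibition, read by CCK-8 assay, with a stated time of 48 h; on this read-out higher numbers stand for weaker inhibition of growth and lower numbers for stronger inhibition of growth. Compound 1 `Cc1ccc(Nc2ncc(Cl)c(Nc3ccccc3C)n2)cc1` gives in this assay only a limit of the assay, > 100000 nM. Compound 2 `Cc1ccccc1Nc1nc(NCc2ccco2)ncc1Cl` likewise gives only a limit, > 100000 nM. Among the compounds with values here, compound 3 `CN1CCN(c2ccc(Nc3ncc(Cl)c(NCc4ccco4)n3)nc2)CC1` is the one compound with a number: in this assay compound 3 gives 11000 nM. Compound 1 and compound 2 differ in a single place, (4-methylphenyl in place of (furan-2-yl)methyl on a nitrogen on an aromatic ring), and the step that the two limits leave unreadable from compound 2 to compound 1 is left unreadable by the limit of > 100000 nM in this assay, at which 2 of the 3 values shown sit. The difference between the cores of compound 2 and compound 3 is not broken down here. Compound 4 `Cc1ccc(Nc2nc(Nc3ccc(N4CCN(C)CC4)cn3)ncc2Cl)cc1` has not yet been measured; it differs from compound 3 by 4-methylphenyl in place of (furan-2-yl)methyl on a nitrogen on an aromatic ring, the same change that leads from compound 2 to compound 1, at a place described in the same words. Within the data shown here, the one measured instance of this change has no readable size, so for compound 4 the expected step is estimated at a 1.4-fold higher number from compound 3 to compound 4 (0.13 log units; within the scatter), close to no change. Compound 4 is estimated at 15000 nM in this assay, with a range from 3000 nM to 80000 nM.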

Compound 4, concentration for 50% growth inhibition: 4030 nM
The estimate for compound 4 lay 3.7-fold (0.57 log units) above the measured number; the measured number falls inside the stated range.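

In this assay, putting 4-methylphenyl in place of (furan-2-yl)methyl on the core of compound 3 gives a 2.7-fold lower number from compound 3 to compound 4 (0.44 log units; beyond the scatter), so on this one core the change has a readable size and the number falls. The same change from compound 2 to compound 1 cannot be read, because compound 2 and compound 1 each give only a limit of the assay: the limit of > 100000 nM in this assay, at which 2 of the 4 values shown sit. The series therefore holds a single readable instance of this change, which does not show that the step carries from one core to another, in either size or direction.

The compounds shown leave open whether the lower number is tied to the 4-methylphenyl group itself or would also appear with other groups on that nitrogen on an aromatic ring. A longer carbon chain or a carboxylic acid at that place would speak to this, and the outcome of either on the core of compound 3 remains an open question.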